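This account rests on a few compounds, and the source may have more. Where it says the series, first, only, none or still open, it means among the compounds named here.

Of the compounds shown here, three that share one core have been tested in an ADME assay on THP-1 cells (Homo sapiens) for cytotoxicity, read by MTT assay, tested at 50 ug/mL; on this read-out higher numbers stand for more inhibition at the one concentration tested (going by the name of the read-out) and lower numbers for less inhibition. Compound 1 `Fc1ccc(-c2csc(N/N=C/c3ccc(-n4cncn4)cc3)n2)cc1` gives 35.9% there. Compound 2 `Brc1ccc(-c2csc(N/N=C/c3ccc(-n4cncn4)cc3)n2)cc1` gives 32.6%. Compound 3 `COc1ccc(-c2csc(N/N=C/c3ccc(-n4cncn4)cc3)n2)cc1` gives 23%. Among these three numbers compound 3 sits lowest, yet its gap to compound 2 lies within the scatter, so only its gap to compound 1 counts as a real difference.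

Compound 4 `O=[N+]([O-])c1ccc(-c2csc(N/N=C/c3ccc(-n4cncn4)cc3)n2)cc1` has not yet been measured. It differs from compound 3 in one place: nitro in place of methoxy on an aromatic carbon. The change sits where the three measured compounds already differ from one another, so the two steps leading into compound 3 are the ones that bear on it. The step of a number 12.9 percentage points lower from compound 1 to compound 3 (beyond the scatter) is the larger of the two, and the step of a number 9.6 percentage points lower from compound 2 to compound 3 (within the scatter) is the smaller. All three measured numbers lie close together, and none of them shows how a nitro group behaves at that place. Compound 4 is therefore expected to land near the measured three. The step of a number 7 percentage points higher from compound 3 to compound 4 (within the scatter) is expected, a move that would not stand out from the scatter. The estimate for compound 4 is 30%, with a range from 15% to 45%.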

Compound 4, a percentage reported as inhibition, at one concentration (the size of the read-out at that concentration, not a potency): 12.9%
The estimate for compound 4 lay 17.1 percentage points above the measured number, and the stated range ends above it.
By their numbers in this assay, from the lowest: compound 4; then compounds 3, 2 and 1 (each within the scatter of the next, the first and the last beyond it).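

At this position, on the aromatic carbon para to a large group, the change from methoxy to nitro in this assay gives a number 10.1 percentage points lower from compound 3 to compound 4 (beyond the scatter), so the substituent here can still lower the number even when the starting point is already the lowest of the earlier set. Going by these compounds alone, the replacements of the two halogens are larger, with a number 19.7 percentage points lower from compound 2 to compound 4 (beyond the scatter) and a number 23 percentage points lower from compound 1 to compound 4 (beyond the scatter), which makes compound 4 the only compound set apart from all the others; among the earlier three, only the fluoro and methoxy compounds were separated from each other. Nothing available here explains why the nitro group gives the lowest number, so the result stands as an observation without a cause.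

Four groups at one place cannot show whether the number follows any general rule, and an amine, a carboxylic acid or a plain hydrogen at this same carbon could fall anywhere relative to these values. From the compounds shown here alone, it also remains open whether a nitro group elsewhere on this ring, or on another part of the shared core, would give a similar number.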